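From dimethylmorpholine amide to phenylethyl amide

This account rests on a few compounds, and the source may have more. Where it says the series, first, only, none or still open, it means among the compounds named here.

Measured in a functional assay on MX1 cells (Homo sapiens) for inhibition, read by MTT assay, with a stated time of 120 h; a lower number here means a stronger inhibitor, a higher number a weaker inhibitor:
- compound 1 `CC1CN(C(=O)c2ccc(-c3ccc(NC(=O)Nc4ccc(Cl)c(C(F)(F)F)c4)cc3)cc2)CC(C)O1`: > 50000 nM (a limit, not a number)
- compound 2 `O=C(/C=C/c1ccc(NC(=O)Nc2ccc(Cl)c(C(F)(F)F)c2)cc1)NC1CCC1`: 4530 nM

On these data alone, compound 1 gives only a limit, > 50000 nM, so its true position in this assay is unknown. In the pair measured so far, (the limit of > 50000 nM in this assay, at which 1 of the 2 values shown sits). Compound 2 has a numerical value, 4530 nM.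

The next compound is compound 3 `CC(NC(=O)c1ccc(-c2ccc(NC(=O)Nc3ccc(Cl)c(C(F)(F)F)c3)cc2)cc1)c1ccccc1`, where (1-phenylethyl)amino replaces 2,6-dimethylmorpholin-4-yl on a carbonyl carbon: (1-phenylethyl)amino in place of 2,6-dimethylmorpholin-4-yl on a carbonyl carbon. For the measured compounds named here, no measured step covers this change, so the expectation is weak, and compound 2 at 4530 nM is its only numerical reference. A move toward stronger inhibition is expected, shown by the estimated at least 3.3-fold lower number from compound 1 to compound 3 (0.52 log units; beyond the scatter). Another limit reading remains possible. Compound 3 is expected at 15000 nM, with an estimated range of 4000 nM to 50000 nM.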

Compound 3, half-maximal inhibitory concentration: 4630 nM
The estimate for compound 3 lay 3.2-fold (0.51 log units) above the measured number; measured number inside the range.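

In this assay, (1-phenylethyl)amino in place of 2,6-dimethylmorpholin-4-yl on a carbonyl carbon gives an at least 10-fold lower number from compound 1 to compound 3 (1.03 log units; beyond the scatter), so the group at this position bears on the read-out in this biaryl-free wording of the shared core. The change brings in a hydrogen-bond donor and a carbon-only aromatic ring together, and this single step cannot separate the two. The step is a bound and not a measured size, because compound 1 gives only a limit: the limit of > 50000 nM in this assay, at which 1 of the 3 values shown sits.

Open, on these data alone, is which part of the entering group carries the step: a cyclohexylamino group on the same carbonyl carbon would keep the amide hydrogen without the aromatic ring. Also open, as far as these compounds go, is the part played by the methyl branch, which a benzylamino group would address.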